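This account rests on a few compounds, and the source may have more. Where it says the series, first, only, none or still open, it means among the compounds named here.

Measured so far in a functional assay on G-361 cells (Homo sapiens) for antiproliferative activity, with a stated time of 72 h; on this read-out higher numbers stand for weaker inhibition and lower numbers for stronger inhibition:
compound 1 `OC[C@H]1O[C@@H](n2cnc3c(NCc4ccccc4F)ncnc32)[C@H](O)[C@@H]1O`: "not determined" (no result reported)
compound 2 `Cc1cccc(CNc2ncnc3c2ncn3[C@@H]2O[C@H](CO)[C@@H](O)[C@H]2O)c1`: > 166000 nM, a limit of the assay
compound 3 `OC[C@H]1O[C@@H](n2cnc3c(NCc4ccc(F)cc4F)ncnc32)[C@H](O)[C@@H]1O`: > 166000 nM, also a limit of the assay

Compound 1 has no number in this assay; its result is simply not reported. The two values that stand beside it are limits rather than numbers, so compound 1 cannot be placed relative to them. The change to compound 4 `OC[C@H]1O[C@@H](n2cnc3c(NCc4ccc(F)cc4Cl)ncnc32)[C@H](O)[C@@H]1O` is 2-chloro-4-fluorophenyl in place of 2-fluorophenyl on a saturated chain carbon bound to a nitrogen on an aromatic ring. Going by the values given here, the only measured step, a step that the two limits leave unreadable from compound 2 to compound 3, also exchanges the ring on that carbon, but its size cannot be read. Among the compounds with values here, what the measurements do show is the limit of > 166000 nM in this assay, at which 2 of the 3 values shown sit, which leaves no expectation of a step in this assay in either direction. Compound 4 is therefore estimated at 166000 nM, with a range from 50000 nM to 500000 nM, and most likely it too will be reported only as a limit.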

Compound 4, half-maximal inhibitory concentration: > 166000 nM
Compound 4 gave a limit, no number; the forecaster's own chance of this, stated with the estimate: 85%; the middle value lies on the limit itself.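

Going by these compounds alone, compound 2, compound 3 and compound 4 all give only limits in this assay, so no step among them can be read. The compounds shown leave open whether any of these rings gives a measurable potency, and where compound 1 stands.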